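Widening the amide substituent in a shared core series

The source may report more compounds than this note shows. Statements on the series, on what has been measured and on what is new or still open speak of the compounds shown alone.

Three compounds share one core and differ only in the group hung on an aromatic nitrogen. Compound 1 `CCCCCCCCCCn1cc(Cn2nc(N)c3c(C(F)(F)F)cc(-c4ccccc4)nc32)nn1` carries a decyl chain there and in a functional assay on THP-1 cells (Homo sapiens) for cytotoxicity, read by MTT assay, with a stated time of 24 h (a lower number here means a stronger inhibitor, a higher number a weaker inhibitor), compound 1 gives 48.7 ug/mL. Compound 2 `Nc1nn(Cc2cn(-c3ccc(O)c([N+](=O)[O-])c3)nn2)c2nc(-c3ccccc3)cc(C(F)(F)F)c12` carries a 4-hydroxy-3-nitrophenyl group and gives 36.3 ug/mL in this assay. Compound 3 `Nc1nn(Cc2cn(CC(=O)Nc3ccc(F)cc3)nn2)c2nc(-c3ccccc3)cc(C(F)(F)F)c12` carries a ((4-fluorophenyl)carbamoyl)methyl group and gives 49.6 ug/mL. The steps of a 1.0-fold higher number from compound 1 to compound 3 (0.01 log units; within the scatter) and a 1.4-fold higher number from compound 2 to compound 3 (0.14 log units; within the scatter) show that even a complete swap of this group moved the number very little, so compound 3 sits with the other two rather than apart from them.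

Compound 4 `Nc1nn(Cc2cn(CC(=O)Nc3c(F)cccc3F)nn2)c2nc(-c3ccccc3)cc(C(F)(F)F)c12` differs from compound 3 by a smaller change: 2,6-difluorophenyl in place of 4-fluorophenyl on an amide-type nitrogen. Going by the values given here, no measured pair tests this exact change, but the two measured steps that reach compound 3, a 1.0-fold higher number from compound 1 to compound 3 (0.01 log units; within the scatter) and a 1.4-fold higher number from compound 2 to compound 3 (0.14 log units; within the scatter), involved far larger rearrangements of the same region and stayed within the scatter. The step of a 1.0-fold lower number from compound 3 to compound 4 (0.01 log units; within the scatter) is therefore expected to stay within the scatter as well. Compound 4 is estimated at 48 ug/mL, in the range 24 ug/mL to 96 ug/mL.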

Compound 4, half-maximal inhibitory concentration: 43.3 ug/mL
Compound 4: the middle estimate sits 1.1-fold (0.04 log units) above what was measured, and the stated range covers the measured number.
By their numbers in this assay, from the lowest: compounds 2, 4, 1 and 3 (each within the scatter of the next).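

Going by these compounds alone, the step of a 1.1-fold lower number from compound 3 to compound 4 (0.06 log units; within the scatter) is the first direct test within the amide series, and in this assay it shows that 2,6-difluorophenyl in place of 4-fluorophenyl on the amide-type nitrogen leaves the number within the scatter. The new amide also stays within the scatter of both the decyl and the 4-hydroxy-3-nitrophenyl compounds, as shown by a 1.1-fold lower number from compound 1 to compound 4 (0.05 log units; within the scatter) and by a 1.2-fold higher number from compound 2 to compound 4 (0.08 log units; within the scatter), so all four groups shown give numbers that cannot be told apart here. No supporting measurement explains why these numbers stay together.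

From the compounds shown here alone, whether an amine or a carboxylic acid in place of the fluorines would move the number beyond the scatter remains open. The shared core is also constant across these compounds, leaving open what a methyl group in place of its trifluoromethyl would do.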